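Putting a methyl back on compound 2

The source may hold more compounds than are shown below. What is called first, only, known or untested is meant among the compounds shown, and "the series" means these compounds.

Among the measured compounds shown here, in a functional assay on OVCAR-5 cells (Homo sapiens) for inhibition, with a stated time of 48 h, tested at 50 uM (a higher number here means more inhibition of growth at the concentration tested, a lower number less inhibition of growth), compound 1 (`COc1ccc(/C=C/[C@@](C)(/C=C/c2ccc(O)cc2)CCC=C(C)C)cc1`) gives 20%, while compound 2 (`CC(C)=CCCC(C)(/C=C/c1ccc(O)cc1)/C=C/c1ccc(O)cc1`) gives 33%, the higher of the two numbers measured so far. Compound 3 (`COc1ccc(/C=C/[C@](C)(/C=C/c2ccc(O)cc2)CCC=C(C)C)cc1`) has not yet been measured. It departs from compound 2 by this change: methyl in place of hydrogen on an oxygen on an aromatic ring. In words, it carries methyl in place of hydrogen on an oxygen on an aromatic ring.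

For the measured compounds named here, the one measured step that bears on this is the opposite change, hydrogen in place of methyl on an oxygen on an aromatic ring: a number 13 percentage points higher from compound 1 to compound 2 (beyond the scatter). A single step is slim evidence, but it points to a drop of similar, modest size in this assay. The expected step is a number 12 percentage points lower from compound 2 to compound 3 (beyond the scatter). For compound 3 the estimated value is 21%, with an expected range of 10% to 32%.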

Compound 3, percent growth inhibition at one concentration: 67%
Beside the measured number, compound 3's estimate is 46 percentage points below it; measured number outside the range, above it.
By their numbers in this assay, from the lowest: compound 1; then compound 2; then compound 3.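

In this assay, methyl in place of hydrogen on an oxygen on an aromatic ring no longer acts in one direction: it lowers the number when the stereocentre is drawn as in compound 1, yet with the opposite configuration the same change gives a number 34 percentage points higher from compound 2 to compound 3 (beyond the scatter). Between the two methylated compounds the result is a number 47 percentage points higher from compound 1 to compound 3 (beyond the scatter), and this gap can be traced to one difference only: the fact that compounds 1 and 3 differ only in the configuration as drawn. The effect of this methyl therefore cannot be read without the configuration at the saturated chain carbon.

On these data alone, whether a longer chain on that oxygen, such as ethyl, would show the same dependence on configuration stays open. As far as these compounds go, each number is also a reading at one concentration, so how the compounds compare across a range of concentrations is unknown.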